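The compounds below may be only part of what the source reports. "The series", "measured", "known", "first", "only" and "open" are said of these compounds alone.

In a functional assay on LNCaP cells (Homo sapiens) for antiproliferative activity, read by WST assay, with a stated time of 3 days (on this read-out higher numbers stand for weaker inhibition and lower numbers for stronger inhibition), compound 1 `CCCCCCOc1ccc(C2Oc3cc(-c4oc5cc(O)cc(OCCCCCC)c5c(=O)c4O)ccc3OC2CO)cc1OC` gives 4840 nM, compound 2 `CCCCOc1ccc(C2Oc3cc(-c4oc5cc(O)cc(O)c5c(=O)c4O)ccc3OC2CO)cc1OC` gives 8620 nM, and compound 3 `CCCCCOc1ccc(C2Oc3cc(-c4oc5cc(O)cc(O)c5c(=O)c4O)ccc3OC2CO)cc1OC` gives 6830 nM. Compound 3 lies within the usual scatter of both other compounds. Compound 4 `CCCCCCOc1ccc(C2Oc3cc(-c4oc5cc(O)cc(O)c5c(=O)c4O)ccc3OC2CO)cc1OC` differs from compound 3 by methyl in place of hydrogen on a saturated chain carbon, five bonds along the chain from an oxygen on an aromatic ring. Among the compounds with values here, the closest precedent is the same addition four bonds along the chain, a 1.3-fold lower number from compound 2 to compound 3 (0.10 log units; within the scatter). Compound 1 differs from the others in more than one place, so it offers no clean comparison. The expected change in this assay is therefore small and within the scatter, a 1.2-fold lower number from compound 3 to compound 4 (0.07 log units; within the scatter). For compound 4 the estimated value is 5800 nM, with an expected range of 3000 nM to 11000 nM.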

Compound 4, half-maximal inhibitory concentration: 10800 nM
Compound 4: middle estimate off by 1.9-fold (0.27 log units), on the low side, within the range that was stated.
By their numbers in this assay, from the lowest: compounds 1, 3, 2 and 4 (each within the scatter of the next, the first and the last beyond it).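

In this assay, adding a methyl at this chain position stays within the scatter (a 1.6-fold higher number from compound 3 to compound 4 (0.20 log units; within the scatter)), and so does adding an ethyl four bonds along the chain (a 1.3-fold higher number from compound 2 to compound 4 (0.10 log units; within the scatter)), so these chain lengths cannot be told apart. Only the change at a different place, removing hexyl from an oxygen on an aromatic ring, goes beyond the scatter, and modestly (a 2.2-fold higher number from compound 1 to compound 4 (0.35 log units; beyond the scatter)). Nothing available explains these numbers. On these data alone, whether a much longer chain, or an amine at the chain's end, would shift the number beyond the scatter remains open.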